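Dropping the Methoxy Group: Compound 1 to Compound 4

The source may hold more compounds than are shown below. What is called first, only, known or untested is meant among the compounds shown, and "the series" means these compounds.

This set of amides was tested in an assay for inhibition of HSP60/HSP10 (Homo sapiens), with a stated time of 60 min; a lower number here means a stronger inhibitor, a higher number a weaker inhibitor. Compound 1 `COc1ccc(Br)cc1C(=O)Nc1ccc(Sc2nc3ccccc3s2)cc1` gives > 100000 nM in this assay, and that figure is a limit of the assay rather than a measured number. Compound 1 therefore stands at the weak end of what is shown, at the limit of > 100000 nM in this assay, at which 1 of the 3 values shown sits. Two measured companions give numbers: compound 2 `O=C(Nc1ccc(Sc2nc3ccccc3s2)c(Cl)c1)c1cccc(Br)c1O` gives 6900 nM in this assay, and compound 3 `O=C(Nc1ccccc1)c1cc(Br)cc(Br)c1O` gives 63000 nM in this assay.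

Compound 4 `O=C(Nc1ccc(Sc2nc3ccccc3s2)cc1)c1cc(Br)cc(Br)c1` has not yet been measured. It differs from compound 1 in one place: 3,5-dibromophenyl in place of 5-bromo-2-methoxyphenyl on a carbonyl carbon. The shared core of compound 1 is kept, and only the ring attached to the carbonyl carbon changes.

Among the measured compounds shown here, no measured pair in this set shows exactly this kind of exchange, so the size of the step has to be guessed from what the three measured compounds show. Compound 1 sits at the limit, and compound 3, which also carries two bromines, is itself weak. The expected step from compound 1 to compound 4 is an at least 2.0-fold lower number from compound 1 to compound 4 (0.30 log units; that floor lies within the scatter), a modest gain at most. Compound 4 is estimated at 50000 nM in this assay, with a likely range from 10000 nM to 150000 nM, and a real chance that only a limit is reported.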

Compound 4, half-maximal inhibitory concentration: > 100000 nM
Compound 4 gave a limit, no number; the forecaster's own chance of this, stated with the estimate: 40%; at least 2.0-fold (0.30 log units) between middle value and limit.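

Compound 4 gives > 100000 nM, which is a limit and not a measured number. Compound 1 also stands at a limit, so no step from compound 1 to compound 4 can be read: the limit of > 100000 nM in this assay, at which 2 of the 4 values shown sit.

The compounds shown leave open whether 3,5-dibromophenyl or 5-bromo-2-methoxyphenyl on the carbonyl carbon gives the stronger inhibitor.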